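The compounds below may be only part of what the source reports. "The series", "measured", "known", "first", "only" and "open" are said of these compounds alone.

In an ADME assay on HepG2 cells (Homo sapiens) for cytotoxicity, read by CellTiter-Glo and resazurin assay, with a stated time of 72 h (a higher number here means that more compound is needed for the effect, a lower number that less compound is needed), compound 3, `CCOC(=O)CCCCCOc1cccc(CN(C(=O)c2ccc(-c3cnc(OC)nc3OC)cc2)C(C)C)c1`, returns only a limit, > 26000 nM. The two other measured compounds stand at the same point. Compound 2, `CCOC(=O)CCCCCOc1cccc(CN(C(=O)c2ccccc2)C(C)C)c1`, gives a limit of > 26000 nM in this assay. Compound 1, `CC(C)COc1cccc(-c2ccc(C(=O)N(Cc3cccc(OCCCCCC(=O)O)c3)C(C)C)cc2)c1`, likewise gives a limit, > 26000 nM. Among the measured compounds shown here, the one step between measured compounds, a step that the two limits leave unreadable from compound 2 to compound 3, cannot be sized because of the limit of > 26000 nM in this assay, at which 3 of the 3 values shown sit, so no step of readable size exists in this assay at all.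

Compound 4, `CCOC(=O)CCCCCOc1cccc(CN(C(=O)c2ccc(-c3cccc(OCC(C)C)c3)cc2)C(C)C)c1`, differs from compound 3 in one place: 3-(isobutoxy)phenyl in place of 2,4-dimethoxypyrimidin-5-yl on an aromatic carbon. For the measured compounds named here, no measured step bears directly on this exchange, and the step from compound 2 to compound 3, which touched the same position, is itself unreadable. Compound 1 carries the same 3-(isobutoxy)phenyl group on its core and sits at the limit as well. On that footing compound 4 is expected to give about 45000 nM in this assay, within a range of 20000 nM to 120000 nM, and most probably to be reported as a limit once more. The step that this estimate implies, a step that the limit leaves unreadable from compound 3 to compound 4, is expected to show no change beyond the scatter.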

Compound 4, half-maximal effective concentration: > 26000 nM
Compound 4: a limit, no number; the forecaster's own chance of this, stated with the estimate: 85%; the middle value does not contradict the limit.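

Compound 4 also returns only a limit in this assay, so its steps from compound 1, compound 2 and compound 3 cannot be read: the limit of > 26000 nM in this assay, at which 4 of the 4 values shown sit.

The compounds shown leave open at what concentration any of them would reach the half-maximal effect, and whether any of these exchanges alters that concentration at all.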